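Swapping the Sulfonyl Aryl: Expected Clearance for Compound 3

A few compounds are considered here, and "the series" means these few. Any claim that something is new, unique, unknown or untested is made for them only; others in the source may bear on it.

Going by the values given here, compound 1 `COc1ccc(-c2c(S(=O)(=O)c3cccc(C#N)c3)cnc3cc(F)ccc23)cc1` is one of two compounds measured in an ADME assay on microsomes from liver (Homo sapiens) for metabolic stability, tested at 2.5 uM (a lower number here means slower removal, a higher number faster removal of the compound), where compound 1 gives 0.92 mL/min. Compound 2 `N#Cc1cccc(S(=O)(=O)c2cnc3cc(F)ccc3c2-c2cccc(Cl)c2)c1` gives 0.99 mL/min in this assay, so the two numbers sit within the scatter of each other. Among the compounds with values here, the single measured step, a 1.1-fold higher number from compound 1 to compound 2 (0.03 log units; within the scatter), swaps the aryl group on the aromatic carbon and leaves the read-out essentially where it was. Compound 3 `COc1ccc(-c2c(S(=O)(=O)c3ccc(OC)cc3)cnc3cc(F)ccc23)cc1` differs from compound 1 at the sulfonyl sulfur instead: 4-methoxyphenyl in place of 3-cyanophenyl on a sulfonyl sulfur. Within the data shown here, no measured step touches this sulfur, so the step from compound 1 to compound 2 bears on it only loosely, as a sign that one aryl swap barely moved the number. With nothing pointing in either direction, compound 3 is expected to give a number near that of compound 1, with a 1.0-fold lower number from compound 1 to compound 3 (0.01 log units; within the scatter) amounting to no change beyond the scatter. The estimate for compound 3 is 0.9 mL/min, with a range from 0.45 mL/min to 1.8 mL/min.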

Compound 3, intrinsic clearance in a liver preparation (reported as CLH), per the amount of preparation that the assay uses: 1.18 mL/min
Compound 3: the middle estimate sits 1.3-fold (0.12 log units) below what was measured; measured number inside the range.
By their numbers in this assay, from the lowest: compounds 1, 2 and 3 (each within the scatter of the next).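

The sulfonyl sulfur now has a measured step of its own in this assay: 4-methoxyphenyl in place of 3-cyanophenyl gives a 1.3-fold higher number from compound 1 to compound 3 (0.11 log units; within the scatter). This shows that exchanging a nitrile-bearing aryl group for a methoxy-bearing one at this position leaves the read-out within the scatter, just as the earlier exchange on the aromatic carbon did (a 1.1-fold higher number from compound 1 to compound 2 (0.03 log units; within the scatter)). Nothing available gives a measured reason for this outcome.

Only two aryl groups on the sulfonyl sulfur are shown, so this result cannot be extended to substituents of a different kind. From the compounds shown here alone, it remains open whether an amine or a carboxylic acid on this aryl ring, or a simple alkyl chain in place of the ring, would keep the number within the scatter of compound 1.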